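Diyne series: terminal vinyl to hydrogen, cytotoxicity notes

The source may hold more compounds than are shown below. What is called first, only, known or untested is meant among the compounds shown, and "the series" means these compounds.

Measured so far:
compound 1 `C=CCCCCCCCC#CC#CC(O)CC(C)=O`: 3.52 ug/mL
compound 2 `C=CCCCCCCCC#CC#CCO`: 3.94 ug/mL
compound 3 `C=CCCCCCCCC#CC#CCOCC(=O)O`: 4.68 ug/mL

Three diynes with a common vinyl-terminated chain have been run in a functional assay on SK-MEL-2 cells (Homo sapiens) for cytotoxicity; a higher number here means that more compound is needed for the effect, a lower number that less compound is needed. Compound 3 carries the highest number of the three, but it sits within the scatter of both others: the gap a 1.2-fold higher number from compound 2 to compound 3 (0.07 log units; within the scatter) and the gap a 1.3-fold higher number from compound 1 to compound 3 (0.12 log units; within the scatter) are each too small to separate the compounds. The third step, a 1.1-fold higher number from compound 1 to compound 2 (0.05 log units; within the scatter), is likewise within the scatter. Every change made so far has been at the end of the chain bearing the oxygen, and none has shifted the read-out beyond its noise.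

Compound 4 `CCCCCCCC#CC#CCOCC(=O)O` is the next member. It differs from compound 3 at the opposite end of the molecule: hydrogen in place of vinyl on a saturated chain carbon, seven bonds along the chain from a triple-bonded carbon. Going by the values given here, no measured step touches this position, so nothing in the data speaks for or against an effect there. Among the compounds with values here, the only guidance is that three variations elsewhere left the number flat, which makes a result near compound 3 the default expectation, with a wider margin because the untried end of the chain is involved. The expected step is a 1.1-fold higher number from compound 3 to compound 4 (0.03 log units; within the scatter), that is, no change beyond the scatter. For compound 4 the estimate in this assay is 5 ug/mL, with a range from 2.3 ug/mL to 11 ug/mL.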

Compound 4, concentration for half-maximal effect: 7.97 ug/mL
The estimate for compound 4 lay 1.6-fold (0.20 log units) below the measured number, within the range that was stated.
By their numbers in this assay, from the lowest: compounds 1, 2, 3 and 4 (each within the scatter of the next, the first and the last beyond it).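

Going by these compounds alone, this is the first change at the end of the chain away from the oxygen, and it replaces vinyl with hydrogen on a saturated chain carbon, seven bonds along the chain from a triple-bonded carbon. In this assay it gives a 1.7-fold higher number from compound 3 to compound 4 (0.23 log units; within the scatter), so compound 3 and compound 4 cannot be separated, and the series keeps a read-out in the same range without the terminal double bond: compound 4 gives 7.97 ug/mL. Nothing available here bears on this result, so the reading rests on this single pair and offers no explanation for the number.

The compounds shown leave open whether the same exchange would also stay within the scatter with the other chain ends, since this pair carries only the carboxymethyl group on the oxygen and has no counterparts for compound 1 or compound 2. They also leave open whether a larger change at this end of the chain, such as a longer chain, a phenyl ring or a terminal amine, would move the number beyond the scatter.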